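The compounds below may be only part of what the source reports. "The series", "measured", "known", "first", "only" and "open" are said of these compounds alone.

Measured compounds:
compound 1, `Cc1nnc(SCc2cc(=O)c3cc(Cl)ccc3o2)o1`: > 25000 nM
compound 2, `Cc1ccc2oc(CSc3nnc(C)s3)cc(=O)c2c1`: > 25000 nM

Both compounds were tested in a functional assay on SW480 cells (Homo sapiens) for cytotoxicity, read by MTT assay, with a stated time of 72 h; on this read-out lower numbers stand for stronger inhibition and higher numbers for weaker inhibition. Compound 1 gives > 25000 nM, which is a limit of the assay and not a number. Compound 2 likewise gives > 25000 nM, again only a limit. Compound 2 therefore stands at the limit, and the other value shown sits there as well (the limit of > 25000 nM in this assay, at which 2 of the 2 values shown sit). Compound 3, `Cc1ccc2oc(CSc3nnc(C)o3)cc(=O)c2c1`, has not yet been measured. It differs from compound 2 in one place: 5-methyl-1,3,4-oxadiazol-2-yl in place of 5-methyl-1,3,4-thiadiazol-2-yl on a sulfur. Among the compounds with values here, no step between two measured compounds is known, so the size of this change cannot be read from the data. With both measured values sitting at the limit, the step expected is a step that the limit leaves unreadable from compound 2 to compound 3, none beyond the scatter. Compound 3 is expected to give about 30000 nM in this assay, within 8000 nM to 120000 nM, most likely again reported only as a limit.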

Compound 3, half-maximal inhibitory concentration: > 25000 nM
Compound 3 ended at the assay's limit; the forecaster's own chance of this, stated with the estimate: 75%; the middle value lies beyond the limit too.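

No step can be read from compound 2 to compound 3 or from compound 1 to compound 3, because all three compounds stop at one limit: the limit of > 25000 nM in this assay, at which 3 of the 3 values shown sit. The compounds shown leave open whether either exchange of groups changes cytotoxicity at all.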